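Adding a hydroxy group to compound 2

A few compounds are considered here, and "the series" means these few. Any claim that something is new, unique, unknown or untested is made for them only; others in the source may bear on it.

Measured in a functional assay on Caco-2 cells (Homo sapiens) for cytotoxicity, read by MTT assay, with stated times of 6 h and 48 h; on this read-out lower numbers stand for stronger inhibition and higher numbers for weaker inhibition:
Compound 1 `Cn1c(/C=C/C(=O)c2cccc(N)c2)cc(Br)c1Br` gives >= 100000 nM (a limit of the assay).
Compound 2 `Cn1c(-c2cc(-c3ccccc3)no2)cc(Br)c1Br` gives 16600 nM.
Compound 3 `Cn1c(-c2cc(-c3ccc[nH]3)no2)cc(Br)c1Br` gives >= 100000 nM (a limit of the assay).

Compound 2 is the only one of the three with a true number, so it has no measured rank above or below a second number. The values of the other two compounds are not numbers but sit at the limit of >= 100000 nM in this assay, at which 2 of the 3 values shown sit.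

Compound 4 `Cn1c(-c2cc(-c3ccccc3O)no2)cc(Br)c1Br` keeps the frame of compound 2 and carries one change: hydroxy in place of hydrogen on an aromatic carbon. Among the measured compounds shown here, only one measured step bears on this change, and it bears indirectly. That step is an at least 6.0-fold higher number from compound 2 to compound 3 (0.77 log units; beyond the scatter). It replaces the whole phenyl group, whereas compound 4 keeps that group and adds hydroxy in place of hydrogen on it. With this single step as a guide, a modest move towards a higher number in this assay is expected, and it may not clear the usual scatter. The expected change is a 2.1-fold higher number from compound 2 to compound 4 (0.32 log units; beyond the scatter). Compound 4 could also reach the limit of the assay. For compound 4 the estimated value is 35000 nM, with an expected range from 10000 nM to 100000 nM.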

Compound 4, half-maximal inhibitory concentration: >= 100000 nM
Compound 4 was reported as a limit; the forecaster's own chance of this, stated with the estimate: 30%; at least 2.8-fold (0.45 log units) between middle value and limit.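

In this assay, a single hydroxy in place of hydrogen on an aromatic carbon, ortho to a large group, is enough for an at least 6.0-fold higher number from compound 2 to compound 4 (0.77 log units; beyond the scatter), even though the phenyl group itself stays in place. The only weakening seen earlier came with the exchange of that whole group, an at least 6.0-fold higher number from compound 2 to compound 3 (0.77 log units; beyond the scatter), so the new step shows that a much smaller change on the phenyl ring can also cost the measurable activity of compound 2. Compound 4 gives >= 100000 nM, which is a limit of the assay, so its step gives only a minimum size and compound 4 joins the compounds at that limit: the limit of >= 100000 nM in this assay, at which 3 of the 4 values shown sit.

How far compound 4 truly lies from compound 2 stays unknown, and the compounds shown do not tell whether the hydroxy group would have the same outcome elsewhere on the ring. Also open, going by these compounds, is whether a methoxy group, a fluorine atom or an amine on the same aromatic carbon would stay close to compound 2, at 16600 nM. Equally open, on these data alone, is whether such groups would likewise reach the limit seen for compound 4.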